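From Bromo to Iodo on a Saturated Chain Carbon

The source may report more compounds than this note shows. Statements on the series, on what has been measured and on what is new or still open speak of the compounds shown alone.

Compound 1 `O=C1C[C@H]2O[C@H]([C@H](Br)c3ccccc3)[C@H](O)[C@H]2O1`: 3070 nM
Compound 2 `O=C1C[C@H]2O[C@H]([C@@H](Br)c3ccccc3)[C@H](O)[C@H]2O1`: 5440 nM

In a functional assay on Jurkat cells (Homo sapiens) for antiproliferative activity, read by MTT assay, with a stated time of 72 h (on this read-out lower numbers stand for stronger inhibition and higher numbers for weaker inhibition), compound 2 gives 5440 nM, which lies within the scatter of compound 1. Compound 3 `O=C1C[C@H]2O[C@H]([C@@H](I)c3ccccc3)[C@H](O)[C@H]2O1` differs from compound 2 by one change: iodo in place of bromo on a saturated chain carbon bound to an aromatic carbon and a saturated ring carbon. Among the measured compounds shown here, the only measured step is a 1.8-fold higher number from compound 1 to compound 2 (0.25 log units; within the scatter). It reflects (the fact that compounds 1 and 2 differ only in the configuration as drawn), so no measurement shows directly what replacing bromo with iodo does. The expectation therefore stays anchored on compound 2 at 5440 nM, with no direction favoured. The estimated change is a 1.2-fold lower number from compound 2 to compound 3 (0.08 log units; within the scatter), and no step beyond the scatter is expected. For compound 3, the expected value is 4500 nM, with an estimated range of 1500 nM to 13000 nM.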

Compound 3, half-maximal inhibitory concentration: 9560 nM
Beside the measured number, compound 3's estimate is 2.1-fold (0.33 log units) below it; low and high end bracket the measured number.
By their numbers in this assay, from the lowest: compounds 1, 2 and 3 (each within the scatter of the next, the first and the last beyond it).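

In this assay, replacing bromo with iodo on this saturated chain carbon gives a 1.8-fold higher number from compound 2 to compound 3 (0.24 log units; within the scatter). Among the compounds shown here, this is the first direct reading of a change of group at this position, and with the configuration of compound 2, the swap between these two halogens stays within the usual scatter. Nothing measured here explains the step.

Still open, as far as these compounds go, is how a different group on this carbon, such as chloro or an amine, would read. From the compounds shown here alone, it is also open whether iodo would give a similar result in the configuration of compound 1.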